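Swapping an isobutyl for a 4-fluorophenyl on a ring nitrogen

This account rests on a few compounds, and the source may have more. Where it says the series, first, only, none or still open, it means among the compounds named here.

compound 1, `COc1cc(-c2nccn2CC(C)C)cc(OC)c1OC`: > 100000 nM
compound 2, `COc1cc(-c2nccn2S(=O)(=O)c2ccc(C)cc2)cc(OC)c1OC`: > 100000 nM

In a functional assay on HT-29 cells (Homo sapiens) for antiproliferative activity, read by MTT assay, with a stated time of 72 h (on this read-out lower numbers stand for stronger inhibition and higher numbers for weaker inhibition), compound 1 gives > 100000 nM, which is a limit of the assay and not a number. Compound 2 likewise reaches only a limit, > 100000 nM. Compound 1 therefore stands at the limit of > 100000 nM in this assay, at which 2 of the 2 values shown sit, with no measured number to compare. Compound 3, `COc1cc(-c2nccn2-c2ccc(F)cc2)cc(OC)c1OC`, differs from compound 1 by 4-fluorophenyl in place of isobutyl on an aromatic nitrogen. Within the data shown here, no measured step between compounds exists here, so the step from compound 1 to compound 3 can only be guessed; it is expected to be an at least 5.0-fold lower number from compound 1 to compound 3 (0.69 log units; beyond the scatter), toward stronger inhibition, though a limit again is quite possible. Compound 3 is expected to give about 20000 nM, between 2000 nM and 100000 nM.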

Compound 3, half-maximal inhibitory concentration: 29300 nM
Beside the measured number, compound 3's estimate is 1.5-fold (0.17 log units) below it, within the range that was stated.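

Of the compounds shown, only one with 4-fluorophenyl on this aromatic nitrogen gives a measured number, so the group here can move the read-out off the limit of the assay. Placing it there in place of isobutyl gives an at least 3.4-fold lower number from compound 1 to compound 3 (0.53 log units; beyond the scatter), toward stronger inhibition. The full size of this step cannot be read, since its starting value is only a limit: the limit of > 100000 nM in this assay, at which 2 of the 3 values shown sit.

On these data alone, whether the fluorine contributes remains open, and a plain phenyl would address that. As far as these compounds go, how a benzyl or an aminoethyl chain on this nitrogen would behave also remains unknown.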